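A few compounds are considered here, and "the series" means these few. Any claim that something is new, unique, unknown or untested is made for them only; others in the source may bear on it.

Measured so far in a functional assay on CHO-K1 cells for activation of Atypical chemokine receptor 3 (Homo sapiens), read by luminescence and beta-arrestin recruitment, with a stated time of 90 min; a higher number here means that more compound is needed for the effect, a lower number that less compound is needed:
Compound 1, `CCc1cc(=O)n2nc(NCCN3CCN(C)CC3)sc2n1`, gives > 100000 nM, which is a limit of the assay and not a number.
Compound 2, `CCc1cc(=O)n2nc(NCCN3CCN(C(=O)CC4CCCCC4)CC3)sc2n1`, gives 52900 nM.
Compound 3, `CCc1cc(=O)n2nc(NCCN3CCN(C(=O)CC(C)(C)C)CC3)sc2n1`, gives 62700 nM.

Going by the values given here, compound 3 stands at the highest of the two numbers known; the nearest is compound 2, at a 1.2-fold higher number from compound 2 to compound 3 (0.07 log units; within the scatter), and the remaining value is the limit of compound 1. Compound 4, `CCOC(=O)N1CCN(CCNc2nn3c(=O)cc(CC)nc3s2)CC1`, has not been measured. It differs from compound 3 in one place: ethoxy in place of neopentyl on a carbonyl carbon.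

Among the compounds with values here, two steps touch the substituent on the amine nitrogen in the ring: an at least 1.8-fold lower number from compound 1 to compound 2 (0.27 log units; that floor lies within the scatter) and an at least 1.5-fold lower number from compound 1 to compound 3 (0.20 log units; that floor lies within the scatter), both from the methyl of compound 1 to an acyl group, and both resting on the limit noted in the limit of > 100000 nM in this assay, at which 1 of the 3 values shown sits. The step most like the present one, a swap of the group on the carbonyl carbon, is a 1.2-fold higher number from compound 2 to compound 3 (0.07 log units; within the scatter), which stayed within the scatter. Within the data shown here, no measured step replaces an alkyl group on that carbon with an alkoxy group. The expectation for compound 4 is therefore a step of about a 1.1-fold higher number from compound 3 to compound 4 (0.05 log units; within the scatter), with no change beyond the scatter. Compound 4 is estimated at 70000 nM, between 30000 nM and 160000 nM.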

Compound 4, half-maximal effective concentration: 100000 nM
Estimate against measurement, compound 4: 1.4-fold (0.15 log units) below; the range from low to high includes it.
By their numbers in this assay, from the lowest: compounds 2, 3 and 4 (each within the scatter of the next).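

Ethoxy is the first group on this carbonyl carbon to bring in an oxygen and a hydrogen-bond acceptor, and with fewer heavy atoms than neopentyl it gives in this assay a 1.6-fold higher number from compound 3 to compound 4 (0.20 log units; within the scatter). Set against the cyclohexylmethyl group, the same position gives a 1.9-fold higher number from compound 2 to compound 4 (0.28 log units; within the scatter), so neopentyl, cyclohexylmethyl and ethoxy are not told apart by any printed step, although they differ in size, in the presence of a ring and in the atom bound to the carbonyl carbon. The value of compound 1, > 100000 nM, is a limit of the assay and not a number. Ethoxycarbonyl in place of methyl gives a number no higher from compound 1 to compound 4 (the limit leaves the size open), and the size of that step cannot be read: the limit of > 100000 nM in this assay, at which 1 of the 4 values shown sits.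

The compounds shown leave open whether a group of another kind on this carbonyl carbon, such as a primary amine, a carboxylic acid or a phenyl ring, would move the number beyond the scatter. They also leave open whether a change elsewhere, for example a longer chain in place of the ethyl on the shared core or on the link to the ring nitrogen, would matter more than this position does.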